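The compounds below may be only part of what the source reports. "The series", "measured", "known", "first", "only" and "open" are said of these compounds alone.

Compound 2, `Cc1nc(N2CCC(O)CC2)nc2ccc(NC(=O)/C=C/c3ccc(Cl)cc3)cc12`, is the weaker of the two compounds measured in a functional assay on CHO-K1 cells for antagonist activity at melanin-concentrating hormone receptor 1 (Homo sapiens), read by inositol phosphate accumulation, with stated times of 10 min and 45 min; on this read-out higher numbers stand for weaker inhibition and lower numbers for stronger inhibition: compound 2 gives 73 nM, while compound 1, `Cc1nc(N2CCC(N3C(=O)CCC3=O)CC2)nc2ccc(NC(=O)/C=C/c3ccc(OC(F)(F)F)cc3)cc12`, gives 35 nM. Compound 3, `Cc1nc(N2CCC(N3CCCC3=O)CC2)nc2ccc(NC(=O)/C=C/c3ccc(Cl)cc3)cc12`, has not yet been measured; it differs from compound 2 by 2-oxopyrrolidin-1-yl in place of hydroxy on a saturated ring carbon. Among the measured compounds shown here, with no comparable step among the measured pair, a modest step toward stronger inhibition is expected, a 1.8-fold lower number from compound 2 to compound 3 (0.26 log units; within the scatter), since compound 1, which also bears a ring group on that saturated ring carbon, gives 35 nM. For compound 3 the estimated value in this assay is 40 nM, with a range from 15 nM to 110 nM.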

Compound 3, half-maximal inhibitory concentration: 20 nM
Compound 3: middle estimate off by 2.0-fold (0.30 log units), on the high side, within the range that was stated.
By their numbers in this assay, from the lowest: compounds 3 and 1 (each within the scatter of the next); then compound 2.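

In this assay, replacing hydroxy with 2-oxopyrrolidin-1-yl on this saturated ring carbon gives a 3.7-fold lower number from compound 2 to compound 3 (0.56 log units; beyond the scatter). This position therefore tolerates a larger group containing a five-membered ring, and the hydrogen-bond donor of hydroxy is not needed for inhibition at this level. Nothing available explains why the number falls. From the compounds shown here alone, it remains open whether the ring or its carbonyl matters more. An open-chain acetamide or a simple amine on the same carbon would help separate those two possibilities.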